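The source may report more compounds than this note shows. Statements on the series, on what has been measured and on what is new or still open speak of the compounds shown alone.

Compound 1 `CC(C)(C)c1cc(-c2cc(=O)c3ccc(OCCO)cc3o2)cc(C(C)(C)C)c1O` and compound 2 `CC(C)(C)c1cc(-c2cc(=O)c3ccc(OCc4ccc5ccccc5n4)cc3o2)cc(C(C)(C)C)c1O` share one core and differ only at the saturated chain carbon bound to an oxygen on the aromatic ring. In a functional assay for inhibition (on this read-out higher numbers stand for weaker inhibition and lower numbers for stronger inhibition), compound 1 gives 3000 nM, and in this assay compound 2 gives 3000 nM; the step of no change at the digits printed from compound 1 to compound 2 (within the scatter) is within the scatter, so compound 2 stands level with compound 1. Compound 3 `CC(C)(C)c1cc(-c2cc(=O)c3ccc(OCCCS(=O)(=O)O)cc3o2)cc(C(C)(C)C)c1O` carries the change (2-sulfoethyl in place of quinolin-2-yl on a saturated chain carbon bound to an oxygen on an aromatic ring). Within the data shown here, the one measured step bears on it only loosely, since neither measured group resembles the entering one; no shift beyond the scatter is expected, no change at the digits printed from compound 2 to compound 3 (within the scatter). Compound 3 is therefore estimated at 3000 nM, between 1000 nM and 10000 nM.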

Compound 3, half-maximal inhibitory concentration: 500 nM
Compound 3: the middle estimate sits 6.0-fold (0.78 log units) above what was measured, and the stated range ends above it.
By their numbers in this assay, from the lowest: compound 3; then compounds 1 and 2 (each within the scatter of the next).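

Up to this point, the group at this position had made no difference in this assay, but the sulfo-bearing chain shows that the position does respond to what it carries. Replacing (quinolin-2-yl)methyl with 3-sulfopropyl gives a 6.0-fold lower number from compound 2 to compound 3 (0.78 log units; beyond the scatter), and placing sulfomethyl where the hydroxy stood gives a 6.0-fold lower number from compound 1 to compound 3 (0.78 log units; beyond the scatter), so the two different starting groups lead to the same step. Nothing measured here explains that shift. On these data alone, it remains open whether the sulfo group itself or the chain carrying it matters. A carboxylic acid or an amine at the chain end, or a shorter or longer chain bearing the sulfo group, would separate these.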